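The source may hold more compounds than are shown below. What is called first, only, known or untested is meant among the compounds shown, and "the series" means these compounds.

Working notes on the series. The shared core is that of compound 1 `COc1ccc([C@@H]2CC(=O)c3c(O)cc(OCc4cn(Cc5ccccc5)nn4)cc3O2)cc1O`, which in a functional assay on RAW264.7 cells (Mus musculus) for inhibition, read by Griess assay, with stated times of 2 h and 24 h (on this read-out higher numbers stand for weaker inhibition and lower numbers for stronger inhibition), gives 11000 nM. Compound 2 `COc1ccc([C@@H]2CC(=O)c3c(O)cc(OCc4cn(Cc5cccc(Cl)c5)nn4)cc3O2)cc1O` carries a 3-chlorobenzyl on the ring nitrogen and in this assay gives 18200 nM. Compound 3 `COc1ccc([C@@H]2CC(=O)c3c(O)cc(OCc4cn(C5CCCCC5)nn4)cc3O2)cc1O` carries a cyclohexyl there and in this assay gives 15600 nM; of the three numbers seen so far this is the second highest, nearest to compound 2 and furthest from compound 1, both gaps within the scatter. The measured steps are a 1.7-fold higher number from compound 1 to compound 2 (0.22 log units; within the scatter), a 1.4-fold higher number from compound 1 to compound 3 (0.15 log units; within the scatter) and a 1.2-fold lower number from compound 2 to compound 3 (0.07 log units; within the scatter); none of them leaves the scatter.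

Compound 4 `COc1ccc([C@@H]2CC(=O)c3c(O)cc(OCc4cn(Cc5ccccc5C)nn4)cc3O2)cc1O` differs from compound 3 by 2-methylbenzyl in place of cyclohexyl on an aromatic nitrogen. Going by the values given here, two steps bear on this: a 1.4-fold higher number from compound 1 to compound 3 (0.15 log units; within the scatter), which read backwards is the exchange of cyclohexyl for a benzyl, and a 1.7-fold higher number from compound 1 to compound 2 (0.22 log units; within the scatter), a chloro placed on the benzyl; both lie within the scatter. Among the compounds with values here, the 2-methylbenzyl itself has no precedent. For compound 4 the expected step is therefore a 1.2-fold lower number from compound 3 to compound 4 (0.08 log units; within the scatter), nothing beyond the scatter. In this assay compound 4 is estimated at 13000 nM, with a range from 6000 nM to 30000 nM.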

Compound 4, half-maximal inhibitory concentration: 13100 nM
For compound 4 the middle estimate is 1.0-fold (0.00 log units) below the measured one; the measured number falls inside the stated range.
By their numbers in this assay, from the lowest: compounds 1, 4, 3 and 2 (each within the scatter of the next).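

In this assay the benzyl on the aromatic nitrogen now also tolerates a methyl on an aromatic carbon, which gives a 1.2-fold higher number from compound 1 to compound 4 (0.08 log units; within the scatter) and so adds a second benzyl substituent, after the chloro of compound 2, that stays within the scatter. Exchanging the substituted benzyls directly, 2-methylphenyl in place of 3-chlorophenyl on the saturated chain carbon bound to the aromatic nitrogen, gives a 1.4-fold lower number from compound 2 to compound 4 (0.14 log units; within the scatter), so these two substituted benzyls cannot be told apart here. The 2-methylbenzyl in place of cyclohexyl gives a 1.2-fold lower number from compound 3 to compound 4 (0.08 log units; within the scatter), which means that this substituted aromatic ring and the non-aromatic ring also cannot be separated at this position.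

As far as these compounds go, whether an amine or a carboxylic acid on the benzyl, or a longer chain between the aromatic nitrogen and the ring, would move the number beyond the scatter remains open. Going by these compounds alone, with all four compounds within the scatter of the next, the series so far gives no group at this position a firm place in any order. No measurement at hand offers an explanation for these steps.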